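A few compounds are considered here, and "the series" means these few. Any claim that something is new, unique, unknown or untested is made for them only; others in the source may bear on it.

Compound 1 `CC(C)=CCOc1cc(=O)n(CCCO)c2c1CC(CC=C(C)C)C(C)(C)C2` is the reference point of this account: in a functional assay on PANC-1 cells (Homo sapiens) for inhibition, read by MTT assay, with a stated time of 24 h, tested at 10 uM (a lower number here means less inhibition, a higher number more inhibition at the concentration tested (going by the name of the read-out)), compound 1 gives 20.7%. Compound 2 `CC(C)=CCC1Cc2c(OCCCNS(=O)(=O)c3ccc(C(F)(F)F)cc3)cc(=O)n(CCCO)c2CC1(C)C` gives 29.6% in this assay, a value within the scatter of compound 1, whereas compound 3 `CC(C)=CCC1Cc2c(OCCCNS(=O)(=O)c3ccc([N+](=O)[O-])cc3)cc(=O)n(CCCO)c2CC1(C)C` gives 47.7% in this assay, beyond the scatter of compound 1. Going by the values given here, the only measured step, a number 18.1 percentage points higher from compound 2 to compound 3 (beyond the scatter), concerns a change on a distant aromatic ring and says nothing about the oxygen on the core. Compound 4 `CC(C)=CCC1Cc2c(OC(=O)Nc3cccc(F)c3)cc(=O)n(CCCO)c2CC1(C)C` differs from compound 1 in another way: (3-fluorophenyl)carbamoyl in place of 3-methylbut-2-en-1-yl on an oxygen on an aromatic ring. Among the compounds with values here, no measured step covers this change, so the expected step of a number 9.3 percentage points higher from compound 1 to compound 4 (within the scatter) is small and uncertain. Compound 4 is therefore estimated at 30% in this assay, within 12% to 50%.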

Compound 4, a percentage reported as inhibition, at one concentration (the size of the read-out at that concentration, not a potency): 66.1%
For compound 4 the middle estimate is 36.1 percentage points below the measured one; measured number above the stated range.
By their numbers in this assay, from the lowest: compounds 1 and 2 (each within the scatter of the next); then compound 3; then compound 4.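

On an oxygen on an aromatic ring, (3-fluorophenyl)carbamoyl in place of 3-methylbut-2-en-1-yl gives, in this assay, a large step, a number 45.4 percentage points higher from compound 1 to compound 4 (beyond the scatter), so the read-out responds strongly to what this oxygen carries. The entering group brings an aromatic ring and a hydrogen-bond donor that the leaving group lacks, and this single pair cannot separate their contributions. No measurement offered here explains the rise.

From the compounds shown here alone, the roles of the fluorine, the aromatic ring and the carbamoyl link remain open. Phenylcarbamoyl or ethylcarbamoyl on the same oxygen would help to tell them apart.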